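The source may report more compounds than this note shows. Statements on the series, on what has been measured and on what is new or still open speak of the compounds shown alone.

Of the compounds shown here, three sharing one core have been measured in a functional assay on NCI-H1581 cells (Homo sapiens) for inhibition, read by MTT assay, with a stated time of 48 h, tested at 10 uM; on this read-out higher numbers stand for more inhibition at the one concentration tested (going by the name of the read-out) and lower numbers for less inhibition. Compound 1 `Cc1ccc(Nc2cc(NC(=O)Nc3c(Cl)cccc3Cl)ncn2)cc1F` gives 45.3%, compound 2 `Cc1ccc(Nc2cc(NC(=O)Nc3c(Cl)cccc3Cl)ncn2)cc1C` gives 73.3%, and compound 3 `COc1cc(Br)ccc1Nc1cc(NC(=O)Nc2c(Cl)cccc2Cl)ncn1` gives 47.3%, which leaves compound 3 within the scatter of compound 1 and beyond the scatter only against compound 2. Compound 4 `COc1ccc(Br)cc1Nc1cc(NC(=O)Nc2c(Cl)cccc2Cl)ncn1` is the next step, made by 5-bromo-2-methoxyphenyl in place of 4-bromo-2-methoxyphenyl on a nitrogen on an aromatic ring. The measured steps that bear on it both exchange the whole group on that nitrogen: a number 2 percentage points higher from compound 1 to compound 3 (within the scatter) and a number 26 percentage points lower from compound 2 to compound 3 (beyond the scatter). For the measured compounds named here, no measured step moves only the bromine within an otherwise unchanged ring, so for compound 4 in this assay a step no larger than the scatter is expected, a number 0.3 percentage points lower from compound 3 to compound 4 (within the scatter). Compound 4 is therefore estimated at 47%, between 30% and 65%.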

Compound 4, a percentage reported as inhibition, at one concentration (the size of the read-out at that concentration, not a potency): 53.3%
Beside the measured number, compound 4's estimate is 6.3 percentage points below it; the range from low to high includes it.
By their numbers in this assay, from the lowest: compounds 1, 3 and 4 (each within the scatter of the next); then compound 2.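

Moving the bromine, the only step shown that keeps the same atoms on that nitrogen and changes only how they are joined, has an effect too small to tell from the scatter (a number 6 percentage points higher from compound 3 to compound 4 (within the scatter)). For the compounds shown here, the exchange of the whole group for the one in compound 1 also stays within the scatter (a number 8 percentage points higher from compound 1 to compound 4 (within the scatter)), whereas the exchange from the group in compound 2 goes beyond it (a number 20 percentage points lower from compound 2 to compound 4 (beyond the scatter)). Nothing measured here explains these numbers.

From the compounds shown here alone, it remains open whether an amine in place of the bromine, or ethoxy in place of methoxy, would move the number beyond the scatter. Also open, going by these compounds, is whether 3,4-dimethylphenyl stays ahead of the two bromo groups at other concentrations.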